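Amine Side Chains on a Shared Core: Cytotoxicity Outlook

This account rests on a few compounds, and the source may have more. Where it says the series, first, only, none or still open, it means among the compounds named here.

The measured compounds in a toxicity assay on L02 cells (Homo sapiens) for cytotoxicity, read by MTT assay, with a stated time of 72 h; on this read-out higher numbers stand for weaker inhibition and lower numbers for stronger inhibition:
- compound 1 `O=C1c2c[n+]([O-])c3ccccc3c2C(=O)c2c1c1ccccc1n2Cc1cn(C[C@@H](O)CO)nn1` gives 490 nM
- compound 2 `CC1(C)O[C@@H](CO)[C@H](Cn2cc(Cn3c4c(c5ccccc53)C(=O)c3c[n+]([O-])c5ccccc5c3C4=O)nn2)O1` gives 500 nM
- compound 3 `O=C1c2c[n+]([O-])c3ccccc3c2C(=O)c2c1c1ccccc1n2CCCCN1CCNCC1` gives 1380 nM

Compound 3 has the highest number of the three, and its gaps to compound 1 and compound 2 both lie beyond the scatter, so it is the weakest inhibitor among the measured set. Among the measured compounds shown here, the only change that touched the side chain on the aromatic nitrogen in a way that mattered was a 2.8-fold higher number from compound 1 to compound 3 (0.45 log units; beyond the scatter), a modest move; the change a 1.0-fold higher number from compound 1 to compound 2 (0.01 log units; within the scatter) stayed within the scatter.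

Compound 4 `CN(C)CCCCCn1c2c(c3ccccc31)C(=O)c1c[n+]([O-])c3ccccc3c1C2=O` is compound 3 with one alteration: (dimethylamino)methyl in place of piperazin-1-yl on a saturated chain carbon, four bonds along the chain from an aromatic nitrogen. For the measured compounds named here, no measured step exchanges one basic amine chain for another, so the two steps above bear on this only loosely, as a sign that side-chain edits on this core have shifted numbers by small amounts. The nearest guidance is that compound 3 stands at 1380 nM and that replacing a whole triazole unit cost only a modest step. Compound 4 is therefore expected to stay close to compound 3, with a 1.1-fold higher number from compound 3 to compound 4 (0.04 log units; within the scatter) as the estimated shift, not clearly beyond the scatter. The estimate for compound 4 is 1500 nM, with a range from 600 nM to 3800 nM.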

Compound 4, half-maximal inhibitory concentration: 240 nM
Estimate against measurement, compound 4: 6.3-fold (0.80 log units) above; the whole stated range lies above it.
By their numbers in this assay, from the lowest: compound 4; then compounds 1 and 2 (each within the scatter of the next); then compound 3.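

In this assay, the exchange of piperazin-1-yl for (dimethylamino)methyl on a saturated chain carbon, four bonds along the chain from an aromatic nitrogen, gives a 5.8-fold lower number from compound 3 to compound 4 (0.76 log units; beyond the scatter), so this part of the side chain affects the number even when an amine stays in the chain. Measured against the triazole side chain of compound 1, the two amine chains also fall on opposite sides: one step is a 2.8-fold higher number from compound 1 to compound 3 (0.45 log units; beyond the scatter), the other is a 2.0-fold lower number from compound 1 to compound 4 (0.31 log units; beyond the scatter), so carrying an amine chain does not by itself set the direction of the change. No available evidence explains why the dimethylamino chain gives the lower number.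

The compounds shown leave open which part of the exchange accounts for the step, since the ring, one nitrogen and the hydrogen-bond donor all leave together. A piperidine or morpholine ring on the same chain, or a 4-methylpiperazin-1-yl group, would separate these parts, while a shorter or longer chain ending in dimethylamino would show how far the result depends on chain length.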